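The source may report more compounds than this note shows. Statements on the series, on what has been measured and on what is new or still open speak of the compounds shown alone.

Compound 1 `C(=C/C1CCCCC1)\c1nc2cc(-c3ccccc3)ccc2[nH]1` is the starting point. In a functional assay on HEK293 cells for antagonist activity at transient receptor potential M8 protein (Canis lupus familiaris), read by FLIPR and calcium flux (on this read-out higher numbers stand for weaker inhibition and lower numbers for stronger inhibition), compound 1 gives 110 nM. Compound 2 `Fc1ccccc1-c1ccc2[nH]c(/C=C/C3CCCCC3)nc2c1` carries fluoro in place of hydrogen on an aromatic carbon, and in this assay compound 2 gives 21 nM. That single swap brought a 5.2-fold lower number from compound 1 to compound 2 (0.72 log units; beyond the scatter). For the measured compounds named here, of the two numbers so far, compound 2 holds the lower one, with compound 1 standing beyond the scatter above it.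

Compound 3 `Clc1ccccc1-c1ccc2[nH]c(/C=C/C3CCCCC3)nc2c1` differs from compound 2 by chloro in place of fluoro on an aromatic carbon, at the position ortho to a large group. Going by the values given here, the one measured step, a 5.2-fold lower number from compound 1 to compound 2 (0.72 log units; beyond the scatter), concerns adding a halogen at this very place, not exchanging one halogen for another, so it gives only a loose guide. The expectation for compound 3 is therefore a change within the scatter, a 1.1-fold lower number from compound 2 to compound 3 (0.02 log units; within the scatter). Compound 3 is estimated at 20 nM, with a range from 6 nM to 60 nM.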

Compound 3, half-maximal inhibitory concentration: 8.9 nM
Estimate against measurement, compound 3: 2.2-fold (0.35 log units) above, within the range that was stated.
By their numbers in this assay, from the lowest: compound 3; then compound 2; then compound 1.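

The identity of the halogen at this place matters, not just its presence: in this assay, going from 2-fluorophenyl to 2-chlorophenyl gives a 2.4-fold lower number from compound 2 to compound 3 (0.37 log units; beyond the scatter). Measured against the unsubstituted phenyl, chloro gives a 12-fold lower number from compound 1 to compound 3 (1.09 log units; beyond the scatter), a larger step than the one fluoro gave, so among these three compounds the number falls from hydrogen to fluoro to chloro, and compound 3 has the lowest number so far. Nothing available explains why the two halogens differ.

Three substituents at one place cannot show whether the number would keep falling with a bromo group, or whether a methyl or a methoxy group would serve as well as a halogen. As far as these compounds go, it also remains open whether chloro would have a similar effect elsewhere on this ring.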